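The source may report more compounds than this note shows. Statements on the series, on what has been measured and on what is new or still open speak of the compounds shown alone.

Working notes on the series in a functional assay on HEK293 cells for agonist activity at Bile acid receptor (Homo sapiens); on this read-out lower numbers stand for smaller maximal responses and higher numbers for larger maximal responses.

Compound 1 `CC(C)c1onc(-c2c(Cl)cccc2Cl)c1COc1ccc(NC(=O)c2ccc(C(=O)O)cc2)c(C(F)(F)F)n1` gives 21% in this assay. Compound 2 `Cc1cc(OCc2c(-c3c(Cl)cccc3Cl)noc2C(C)C)ncc1[N+](=O)[O-]` gives 58% in this assay. For the measured compounds named here, of the two numbers measured so far, compound 1 holds the lower one, and its gap to compound 2 lies beyond the usual scatter. Going by the values given here, the two structures differ in more than one place, so no single step between them can be drawn.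

Compound 3 `CC(C)c1onc(-c2c(Cl)cccc2Cl)c1COc1ccc(N(C)Cc2cccc(C(=O)O)c2)c(C(F)(F)F)n1` has not yet been measured in this assay. It differs from compound 1 in one place: (3-carboxybenzyl)(methyl)amino in place of ((4-carboxyphenyl)carbonyl)amino on an aromatic carbon. The change keeps the count of heavy atoms and the number of hydrogen-bond acceptors, while one hydrogen-bond donor and one double bond outside aromatic rings are lost.

Among the compounds with values here, no measured step between two compounds is available, so there is no measured guide for this change, and the expectation rests on compound 1 alone. The expected step is a number 9 percentage points higher from compound 1 to compound 3 (within the scatter), that is, no change beyond the scatter. Compound 3 is therefore estimated at 30% in this assay, with a range from 10% to 60%.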

Compound 3, largest response reached (reported as efficacy), in percent of the reference or control that the assay uses: 89%
Beside the measured number, compound 3's estimate is 59 percentage points below it; the measured number lies above the stated range.
By their numbers in this assay, from the lowest: compound 1; then compound 2; then compound 3.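

In this assay, the aromatic carbon ortho to a trifluoromethyl group proves highly sensitive to the group it carries: (3-carboxybenzyl)(methyl)amino in place of ((4-carboxyphenyl)carbonyl)amino gives a number 68 percentage points higher from compound 1 to compound 3 (beyond the scatter). Both groups have a carboxy substituent on a six-membered aromatic ring of carbon only and the same count of heavy atoms, so neither the presence of the carboxy group nor the size of the group by that count sets the maximal response in this pair; the entering group has one hydrogen-bond donor and one double bond outside aromatic rings fewer. No measured information on the compounds bears on the reason for this step.

The step combines several changes at once, so the share belonging to the linking atoms, the methyl on nitrogen and the placement of the carboxy group on the ring remains unresolved. A (4-carboxybenzyl)(methyl)amino group or a (3-carboxybenzyl)amino group at the same carbon would help separate these contributions.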